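This account rests on a few compounds, and the source may have more. Where it says the series, first, only, none or still open, it means among the compounds named here.

Working notes on the series. Compound 1, `Cc1ccc(-c2ccc(N(C[C@@H](N)CC(C)C)C(=O)[C@@H]3C[C@H]3c3ccccc3)cc2)cc1`, has been measured in a functional assay for agonist activity at G protein-coupled receptor 88 (Homo sapiens), read by HTRF and cAMP accumulation (on this read-out higher numbers stand for an effect only at larger amounts of compound and lower numbers for an effect already at smaller amounts), where compound 1 gives 360 nM. Compound 2, `CC[C@H](C)[C@H](N)CN(C(=O)[C@@H]1C[C@H]1c1ccccc1)c1ccc(-c2ccc(C(F)(F)F)cc2)cc1`, differs in the group on the far aromatic ring of the biaryl and in the side chain; in this assay compound 2 gives 340 nM. Of the two numbers recorded, compound 2 stands at one end, but its gap to compound 1 is within the scatter, so the two compounds are not separated by these data. Going by the values given here, no pair of compounds that differ in one place has been measured.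

Compound 3, `CC[C@H](C)[C@H](N)CN(C(=O)[C@@H]1C[C@H]1c1ccccc1)c1ccc(-c2ccc(Oc3ccccc3)cc2)cc1`, keeps the side chain and the core of compound 2 and changes only the far ring: phenoxy in place of trifluoromethyl on an aromatic carbon. Among the compounds with values here, there is no measured step that bears on this change, so the expectation rests on the two values above alone. The step from compound 2 to compound 3 is expected to be small, if anything a modest loss: a 1.5-fold higher number from compound 2 to compound 3 (0.17 log units; within the scatter). Compound 3 is estimated at 500 nM in this assay, with a range from 150 nM to 2000 nM.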

Compound 3, half-maximal effective concentration: 94 nM
The estimate for compound 3 lay 5.3-fold (0.73 log units) above the measured number, and the stated range ends above it.
By their numbers in this assay, from the lowest: compound 3; then compounds 2 and 1 (each within the scatter of the next).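

In this assay, going by these compounds alone, phenoxy in place of trifluoromethyl on an aromatic carbon gives a 3.6-fold lower number from compound 2 to compound 3 (0.56 log units; beyond the scatter) and is the only step so far between compounds that differ in one place. This position, para to a large group, therefore takes a group with more heavy atoms and an added six-membered aromatic ring, and the number falls beyond the scatter, which compounds 1 and 2, differing in two places, could not show. Nothing at hand bears on why the number falls.

Open, as far as these compounds go, is whether the drop follows the ether oxygen or the added ring, a question that a directly attached phenyl, a benzyl or a methoxy group at this position would address. Also open, from the compounds shown here alone, is whether phenoxy gives a similar step on the side chain of compound 1, and what a fluorine or a nitrile on the phenoxy ring would do.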